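Nitro-sulfonyl benzamides: amide-end variation

The compounds below may be only part of what the source reports. "The series", "measured", "known", "first", "only" and "open" are said of these compounds alone.

Measured compounds:
compound 1, `CCCN(C(=O)CN(C)C(=O)c1ccc(S(C)(=O)=O)c([N+](=O)[O-])c1)c1ccccc1`: > 60000 nM
compound 2, `CN1CCN(C(=O)C2CCN(C(=O)c3ccc(S(C)(=O)=O)c([N+](=O)[O-])c3)CC2)CC1`: > 60000 nM

In an assay on isolated protein for inhibition of thyroid hormone receptor alpha (Homo sapiens), read by fluorescence polarization (a higher number here means a weaker inhibitor, a lower number a stronger inhibitor), compound 1 gives > 60000 nM, which is a limit of the assay and not a number. Compound 2 gives > 60000 nM in this assay, also a limit. Within the data shown here, compound 1 therefore stands only at a limit, and the one other value shown is a limit as well; the two measured compounds sit together at the limit of > 60000 nM in this assay, at which 2 of the 2 values shown sit, so no step between measured compounds can be sized.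

Compound 3, `CC1CCN(C(=O)CN(C)C(=O)c2ccc(S(C)(=O)=O)c([N+](=O)[O-])c2)CC1`, differs from compound 1 by 4-methylpiperidin-1-yl in place of phenyl(propyl)amino on a carbonyl carbon. Among the measured compounds shown here, no measured step resembles this change, so nothing in the data points to any direction; the expectation is no change beyond the scatter, with the step from compound 1 to compound 3 in this assay estimated as a step that the limit leaves unreadable from compound 1 to compound 3. Compound 3 is thus expected to remain at the limit, estimated at 80000 nM with a range of 20000 nM to 300000 nM in this assay.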

Compound 3, half-maximal inhibitory concentration: > 60000 nM
Compound 3: a limit, no number (the forecaster's own chance of this, stated with the estimate: 85%); the middle value lies beyond the limit too.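

No step can be read between compound 1 and compound 3, because the values of both stand at one limit and not at numbers: the limit of > 60000 nM in this assay, at which 3 of the 3 values shown sit.

The compounds shown leave open which amide-end group, if any, would give a number in this assay.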